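Compound 4 against compound 3: same atoms, joined differently

A few compounds are considered here, and "the series" means these few. Any claim that something is new, unique, unknown or untested is made for them only; others in the source may bear on it.

In a functional assay on SK-MEL-2 cells (Homo sapiens) for cytotoxicity (a higher number here means that more compound is needed for the effect, a lower number that less compound is needed), compound 1 (`CC(=O)C(O)C(O)C/C(C)=C\CC[C@H](C)/C=C/C=C(\C)CCCC1=CC(=O)OC1O`) gives 3 ug/mL while compound 2 (`COC1C=C(CCC/C(C)=C/C=C/[C@@H](C)CC/C=C(/C)C[C@H]2OC(=O)C(C)=C2O)C(=O)O1`) gives 10.9 ug/mL as its reading. Compound 3 (`CC1=C(O)[C@@H](C/C(C)=C\CC[C@H](C)/C=C/C=C(\C)CCCC2=CCN(CC(=O)O)C2=O)OC1=O`) stands at > 30 ug/mL as a limit and not a number (the limit of > 30 ug/mL in this assay, at which 1 of the 3 values shown sits) and so has no exact place in the series.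

Compound 4 (`CC1=C(O)[C@@H](C/C(C)=C\CC[C@H](C)/C=C/C=C(\C)CCCC2=CC(=O)N(CC(=O)O)C2)OC1=O`) has the same atoms as compound 3, joined differently (a group of 10 heavy atoms (6 carbon, 1 nitrogen, 3 oxygen; one five-membered non-aromatic ring with 1 hetero atom) in place of a group of 10 heavy atoms (6 carbon, 1 nitrogen, 3 oxygen; one five-membered non-aromatic ring with 1 hetero atom), on a saturated chain carbon, three bonds along the chain from a double-bonded chain carbon) with no change in what is counted. Going by the values given here, no measured step covers a rejoining of this kind. Among the compounds with values here, the one step that bears on it is an at least 2.7-fold higher number from compound 2 to compound 3 (0.43 log units; beyond the scatter) and this is the step that brought in the nitrogen-bearing group. Compound 4 keeps a group of the same counts, so the number is expected to stay high. The expected change is a number no higher from compound 3 to compound 4 (the limit leaves the size open) and no shift beyond the scatter is expected. Compound 4 is estimated at 30 ug/mL with an expected range of 15 ug/mL to 60 ug/mL and a reading given only as a limit is likely.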

Compound 4, concentration for half-maximal effect: > 30 ug/mL
Compound 4: a limit, no number; the forecaster's own chance of this, stated with the estimate: 65%; the middle value lies on the limit itself.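

In this assay, compound 4 reads > 30 ug/mL, which is a limit and not a number. The rejoined group gives an at least 2.7-fold higher number from compound 2 to compound 4 (0.43 log units; beyond the scatter), so at this position, on a saturated chain carbon, the higher number is not confined to the single arrangement of the nitrogen-bearing group in compound 3. The step between compound 3 and compound 4 cannot be read, and any difference between the two arrangements stays hidden at the limit: the limit of > 30 ug/mL in this assay, at which 2 of the 4 values shown sit.

Going by these compounds, how far compound 3 and compound 4 lie beyond the limit remains open. Also open, on these data alone, is whether the carboxylic acid on the nitrogen is tied to the higher number, a question that a methyl ester or a plain methyl group on that nitrogen would address.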